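Removing the amino group from a furan-bearing nucleoside

This account rests on a few compounds, and the source may have more. Where it says the series, first, only, none or still open, it means among the compounds named here.

Compound 3 `COc1nc(N)nc2c1c(-c1ccco1)cn2[C@@H]1O[C@H](CO)[C@@H](O)[C@H]1O` gives only a limit in a functional assay on HL-60 cells (Homo sapiens) for antiproliferative activity, read by XTT assay, with a stated time of 72 h (on this read-out lower numbers stand for stronger inhibition and higher numbers for weaker inhibition), namely > 20000 nM. That puts compound 3 at the limit of > 20000 nM in this assay, at which 1 of the 3 values shown sits, the weakest end of everything measured. Compound 4 `COc1ncnc2c1c(-c1ccco1)cn2[C@@H]1O[C@H](CO)[C@@H](O)[C@H]1O` differs by a single change: hydrogen in place of amino on an aromatic carbon. Within the data shown here, no measured step isolates this change. Among the measured compounds shown here, the only measured step, a 1.6-fold lower number from compound 1 to compound 2 (0.21 log units; within the scatter), concerns compound 1 `COc1ncnc2c1c(-c1ccsc1)cn2[C@@H]1O[C@H](CO)[C@@H](O)[C@H]1O` and compound 2 `COc1ncnc2c1c(-c1cccs1)cn2[C@@H]1O[C@H](CO)[C@@H](O)[C@H]1O`, which both lack the amino group. In this assay compound 1 gives 130 nM. In this assay compound 2 gives 80 nM. Compound 4 shares their core and is expected to land near them, at 120 nM with a range of 30 nM to 800 nM. That estimate means an at least 160-fold lower number from compound 3 to compound 4 (2.22 log units; beyond the scatter), a step far beyond the scatter.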

Compound 4, half-maximal inhibitory concentration: 100 nM
Beside the measured number, compound 4's estimate is 1.2-fold (0.08 log units) above it, and the stated range covers the measured number.
By their numbers in this assay, from the lowest: compounds 2, 4 and 1 (each within the scatter of the next). At a limit, above all of these: compound 3.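

Putting hydrogen in place of amino on this aromatic carbon, between two ring nitrogen atoms, gives an at least 200-fold lower number from compound 3 to compound 4 (2.30 log units; beyond the scatter), the only step among these compounds that lies beyond the scatter. Changing the furan or thiophene group moves far less, with a 1.3-fold higher number from compound 2 to compound 4 (0.10 log units; within the scatter) and a 1.3-fold lower number from compound 1 to compound 4 (0.11 log units; within the scatter). The value for compound 3 is a limit, so the full size of the first step is unknown: the limit of > 20000 nM in this assay, at which 1 of the 4 values shown sits.

Going by these compounds, what a methyl, hydroxyl or dimethylamino group on this carbon would do remains open. So does whether amino has the same effect alongside a thiophen-2-yl group.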